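Adding a Nitro Group: Expected Tolerance of Compound 4

A few compounds are considered here, and "the series" means these few. Any claim that something is new, unique, unknown or untested is made for them only; others in the source may bear on it.

Compound 1, `COc1ccccc1NC(=O)c1c(NO)cc(-c2ccccc2)oc1=O`, gives only a limit in an ADME assay on Huh-7 cells (Homo sapiens) for cytotoxicity, with a stated time of 3 days; a higher number here means that more compound is tolerated, a lower number that less compound is tolerated: > 20000 nM.
Compound 2, `Nc1ccccc1NC(=O)c1c(NO)cc(-c2ccccc2)oc1=O`, also gives only a limit: > 20000 nM.
Compound 3, `O=C(Nc1ccccc1O)c1c(NO)cc(-c2ccccc2)oc1=O`, gives 14000 nM.

Within the data shown here, compound 3 therefore holds the only actual number; the other two values are limits, as the limit of > 20000 nM in this assay, at which 2 of the 3 values shown sit, shows. Compound 4, `O=C(Nc1cc([N+](=O)[O-])ccc1O)c1c(NO)cc(-c2ccccc2)oc1=O`, differs from compound 3 by nitro in place of hydrogen on an aromatic carbon. Among the measured compounds shown here, no measured step introduces a nitro group. The nearest comparisons alter a group on the same ring: an at least 1.4-fold lower number from compound 1 to compound 3 (0.15 log units; that floor lies within the scatter) and an at least 1.4-fold lower number from compound 2 to compound 3 (0.15 log units; that floor lies within the scatter), both resting on a floor that falls within the scatter, so no direction can be read from them. No shift beyond the scatter is therefore expected, and compound 4 is estimated at 14000 nM, between 5000 nM and 30000 nM, the expected step being no change at the digits printed from compound 3 to compound 4 (within the scatter).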

Compound 4, half-maximal cytotoxic concentration: > 20000 nM
Compound 4 ended at the assay's limit; the forecaster's own chance of this, stated with the estimate: 40%; middle value at least 1.4-fold (0.15 log units) from the limit.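

Nitro in place of hydrogen, para to a hydroxy group, is the first change at this spot on the ring, and this assay shows no sign of less compound being tolerated: the result is an at least 1.4-fold higher number from compound 3 to compound 4 (0.15 log units; that floor lies within the scatter). The value of compound 4 is a limit, and the true size of the step cannot be read because of it: the limit of > 20000 nM in this assay, at which 3 of the 4 values shown sit.

As far as these compounds go, what a nitrile or a carboxylic acid in the same place would do in this assay remains open. So does whether nitro would give the same reading with the hydroxy group replaced.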